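Aryl swaps on sulfur: from compound 3 to compound 4

The source may report more compounds than this note shows. Statements on the series, on what has been measured and on what is new or still open speak of the compounds shown alone.

- compound 1 `COc1ccc(SCc2ccc(/C=C/C(=O)Nc3ccccc3N)cc2)cc1OC`: 46%
- compound 2 `Cc1cc(C)cc(SCc2ccc(/C=C/C(=O)Nc3ccccc3N)cc2)c1`: 8.78%
- compound 3 `Cc1ccc(SCc2ccc(/C=C/C(=O)Nc3ccccc3N)cc2)cc1`: 22.9%

In a functional assay on A-375 cells (Homo sapiens) for inhibition, read by CCK-8 assay, with a stated time of 72 h, tested at 2 uM (on this read-out higher numbers stand for more inhibition of growth at the one concentration tested and lower numbers for less inhibition of growth), compound 3 stands second of the three, with 22.9%. Compound 4 `Nc1ccccc1NC(=O)/C=C/c1ccc(CSc2ccc(F)cc2)cc1` carries fluoro in place of methyl on an aromatic carbon, para to a large group. Three measured steps change this same group on sulfur: a number 23.1 percentage points lower from compound 1 to compound 3 (beyond the scatter), modest, a number 14.1 percentage points higher from compound 2 to compound 3 (beyond the scatter), modest, and a number 37.2 percentage points lower from compound 1 to compound 2 (beyond the scatter), large. So the group matters in this assay, but none of these steps is a fluoro-for-methyl exchange, and the direction stays open. No step beyond the scatter is expected, the estimate being a number 3.1 percentage points higher from compound 3 to compound 4 (within the scatter). Compound 4 is expected at 26%, with an estimated range of 11% to 44%.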

Compound 4, percent growth inhibition at one concentration: 28.8%
The estimate for compound 4 lay 2.8 percentage points below the measured number; the measured number falls inside the stated range.
By their numbers in this assay, from the lowest: compound 2; then compounds 3 and 4 (each within the scatter of the next); then compound 1.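

Fluoro in place of methyl at this position changes little in this assay: a number 5.9 percentage points higher from compound 3 to compound 4 (within the scatter). The 4-fluorophenyl group still stands apart from both more substituted aryl groups, with a number 20 percentage points higher from compound 2 to compound 4 (beyond the scatter) and a number 17.2 percentage points lower from compound 1 to compound 4 (beyond the scatter), so among the aryl groups on sulfur shown, the 3,4-dimethoxyphenyl group of compound 1 remains the one with the highest number. No measurement at hand explains these steps.

On these data alone, whether an amine or a carboxylic acid on this same aromatic carbon would move the number stays open. So does whether a single methoxy group would reach the number of compound 1.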